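Swapping (morpholin-4-yl)carbonyl for (diethylamino)methyl

This account rests on a few compounds, and the source may have more. Where it says the series, first, only, none or still open, it means among the compounds named here.

In a physicochemical assay for solubility, measured as kinetic solubility, at pH 7.4 (on this read-out higher numbers stand for higher solubility and lower numbers for lower solubility), compound 1 `COc1cc(N2CCNCC2)ccc1Nc1nc(NC2CCCCC2)c2nc[nH]c2n1` gives 19000 nM and compound 2 `COc1cc(N2CCC(C(=O)N3CCOCC3)CC2)ccc1Nc1nc(NC2CCCCC2)c2nc[nH]c2n1` stands level with it at 19000 nM within the scatter. Compound 3 `CCN(CC)CC1CCN(c2ccc(Nc3nc(NC4CCCCC4)c4nc[nH]c4n3)c(OC)c2)CC1` has (diethylamino)methyl in place of (morpholin-4-yl)carbonyl on a saturated ring carbon and still awaits measurement. Going by the values given here, no measured step here tests that change, so only a modest rise is expected in this assay and perhaps none beyond the scatter. The expected change is a 1.2-fold higher number from compound 2 to compound 3 (0.08 log units; within the scatter) on this estimate. For compound 3 the estimated value is 23000 nM with an expected range from 9000 nM to 60000 nM in this estimate.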

Compound 3, solubility: 19000 nM
Estimate against measurement, compound 3: 1.2-fold (0.08 log units) above; measured number inside the range.
By their numbers in this assay, from the lowest: compounds 1, 2 and 3 (each within the scatter of the next).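

In this assay, (diethylamino)methyl in place of (morpholin-4-yl)carbonyl on a saturated ring carbon gives no change at the digits printed from compound 2 to compound 3 (within the scatter), so this position has now carried a group with no ring as well as one with a ring, with no step beyond the scatter. Setting 4-((diethylamino)methyl)piperidin-1-yl in place of piperazin-1-yl on an aromatic carbon likewise gives no change at the digits printed from compound 1 to compound 3 (within the scatter). Nothing available explains this flat result. Open, from the compounds shown here alone, is whether a carboxylic acid or a longer chain on that saturated ring carbon would move the read-out beyond the scatter.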